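Cytotoxicity tolerance across a shared core: compounds 1 to 4

The compounds below may be only part of what the source reports. "The series", "measured", "known", "first", "only" and "open" are said of these compounds alone.

Three members of the series have been examined in an ADME assay on MT4 cells (Homo sapiens) for cytotoxicity, with a stated time of 5 days; a lower number here means that less compound is tolerated, a higher number that more compound is tolerated: compound 1 `CC(C)(C#Cc1cc(N(C(=O)[C@H]2CC[C@H](C)CC2)[C@H]2CC[C@H](Oc3ccc(=O)[nH]n3)CC2)c(C(=O)O)s1)C(F)(F)F`, compound 2 `CC(C)N(c1cc(C#CC(C)(C)C)sc1C(=O)O)C(=O)[C@H]1CC[C@H](Cl)CC1` and compound 3 `CC(C)(C)C#Cc1cc(N(C(=O)[C@H]2CC[C@H](C)CC2)[C@H]2CC[C@H](OC3COC3)CC2)c(C(=O)O)s1`. Compound 1 reaches only a limit of the assay, > 20000 nM. Compound 2 likewise stops at a limit, > 20000 nM. Compound 3 also gives a limit, > 20000 nM. Compound 2 therefore stands with the other two at the limit of > 20000 nM in this assay, at which 3 of the 3 values shown sit; none of the three values is a number, so no ordering among them can be drawn.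

The next compound, compound 4 `CC(C)N(C(=O)[C@H]1[C@@H]2CCCC[C@@H]21)c1cc(C#CC(C)(C)C)sc1C(=O)O`, differs from compound 2 at a single site: a group of 7 heavy atoms (7 carbon; one three-membered non-aromatic ring of carbon only, one six-membered non-aromatic ring of carbon only) in place of a group of 7 heavy atoms (6 carbon, 1 chlorine; one six-membered non-aromatic ring of carbon only), on a carbonyl carbon. Going by the values given here, no step between two measured compounds of this kind is known, so the size of any effect of this exchange in this assay rests on no measured precedent. Because all three measured compounds sit at the limit of > 20000 nM in this assay, at which 3 of the 3 values shown sit, the expected step in this assay, a step that the limit leaves unreadable from compound 2 to compound 4, is taken to lie within the scatter, with no direction favoured. For compound 4 the estimated half-maximal cytotoxic concentration in this assay is 30000 nM, with a range from 15000 nM to 80000 nM, and most likely only a limit will again be reported.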

Compound 4, half-maximal cytotoxic concentration: > 20000 nM
Compound 4 was reported as a limit; the forecaster's own chance of this, stated with the estimate: 85%; the middle value lies beyond the limit too.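

In this assay compound 4 gives > 20000 nM, a limit and not a number. With compound 2 also reported only as a limit, no step can be read from compound 2 to compound 4: the limit of > 20000 nM in this assay, at which 4 of the 4 values shown sit.

The compounds shown leave open the actual half-maximal cytotoxic concentration of each of the four, and whether any structural exchange among them alters it.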